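The source may hold more compounds than are shown below. What is called first, only, known or untested is meant among the compounds shown, and "the series" means these compounds.

Compounds measured in an in vitro functional assay on 1321-N1 cells for agonist activity at Free fatty acid receptor 1 (Homo sapiens), read by fluorescence, spectrophotometry and calcium flux; on this read-out higher numbers stand for an effect only at larger amounts of compound and lower numbers for an effect already at smaller amounts:
compound 1 `O=C(O)CCc1ccc(C#Cc2ccnc(-c3ccccc3)c2)cc1`: 186 nM
compound 2 `O=C(O)CCc1ccc(C#Cc2ccnc(F)c2)cc1`: 513 nM

Within the data shown here, compound 2 stands at the higher of the two numbers in this assay; the only step, a 2.8-fold higher number from compound 1 to compound 2 (0.44 log units; beyond the scatter), marks the change of fluoro in place of phenyl on an aromatic carbon and lies beyond the scatter.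

Compound 3 `Cc1c(C#Cc2ccc(CCC(=O)O)cc2)ccnc1F` carries methyl in place of hydrogen on an aromatic carbon. Among the measured compounds shown here, no measured step concerns a methyl entering on the shared core; the step from compound 1 to compound 2 changes a different group and gives no guide to the size or direction of this one. With nothing in the series to indicate otherwise, the methyl is expected to move the number by no more than the scatter, and compound 3 is estimated at 450 nM, with a range of 180 nM to 1200 nM, which would be a step of a 1.1-fold lower number from compound 2 to compound 3 (0.06 log units; within the scatter).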

Compound 3, half-maximal effective concentration: 120 nM
For compound 3 the middle estimate is 3.8-fold (0.57 log units) above the measured one; the whole stated range lies above it.
By their numbers in this assay, from the lowest: compounds 3 and 1 (each within the scatter of the next); then compound 2.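

In this assay, methyl in place of hydrogen on the aromatic carbon ortho to the fluoro group gives a 4.3-fold lower number from compound 2 to compound 3 (0.63 log units; beyond the scatter) and so lies beyond the scatter. This position, two atoms from the ring nitrogen, therefore responds to a single added carbon. Among these compounds, it also gives the first step towards a lower number, and it does so with the fluoro group kept in place.

Going by these compounds, whether an ethyl, a chloro or a methoxy group on this carbon would extend, match or reverse the step remains open. So does whether the methyl would give a similar step with phenyl in place of fluoro, as in compound 1. Nothing available here bears on what lies behind the step.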